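The compounds below may be only part of what the source reports. "The series", "measured", "known", "first", "only" and "open" are said of these compounds alone.

Compound 1 `COc1ccccc1-c1cccc(S(=O)(=O)N2CCC(N3CCC(C)CC3)CC2)c1`: > 5000 nM
Compound 2 `Cc1cc(C)c(S(=O)(=O)N2CCC(N3CCN(C)CC3)CC2)c(C)c1`: > 5000 nM

In an ADME assay on HCT-116 cells (Homo sapiens) for cytotoxicity, read by CellTiter-Glo, with a stated time of 72 h (a lower number here means a stronger inhibitor, a higher number a weaker inhibitor), compound 1 gives only a limit, > 5000 nM. Compound 2 also returns a limit, > 5000 nM, in this assay. Both values therefore sit at the limit of > 5000 nM in this assay, at which 2 of the 2 values shown sit, and no numbered step between measured compounds exists. Compound 3 `CC1CCN(C2CCN(S(=O)(=O)c3cccc(-c4ccccc4C(F)(F)F)c3)CC2)CC1` differs from compound 1 by trifluoromethyl in place of methoxy on an aromatic carbon. Starting from compound 1 at its limit, the expected step that the limit leaves unreadable from compound 1 to compound 3 is none beyond the usual scatter. Compound 3 is therefore expected to give roughly 8000 nM in this assay, somewhere between 3000 nM and 25000 nM, most likely again as a limit rather than a number.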

Compound 3, half-maximal inhibitory concentration: > 5000 nM
Compound 3: only a limit was reported; the forecaster's own chance of this, stated with the estimate: 75%; the middle value is on the limit's open side.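

Within the data shown here, compound 1 and compound 3 each give only a limit in this assay, so no step between them can be read: (the limit of > 5000 nM in this assay, at which 3 of the 3 values shown sit). The compounds shown leave open how strongly any of them acts on these cells, and whether trifluoromethyl in place of methoxy changes that at all.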